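Cytotoxicity in A549 cells: from hydroxypropylamine to benzothiazolylamine

The source may hold more compounds than are shown below. What is called first, only, known or untested is meant among the compounds shown, and "the series" means these compounds.

Compound 2 `Cc1c(Cc2ccccc2)c(=O)oc2cc(OCC(O)CNCCCO)ccc12` was tested in an ADME assay on A549 cells (Homo sapiens) for cytotoxicity, read by CellTiter-Glo (a higher number here means that more compound is tolerated, a lower number that less compound is tolerated), where compound 2 gives 53400 nM. Among the two compounds measured so far, this is the lowest number, though its nearest neighbour, compound 1 `C#CCNCC(O)COc1ccc2c(C)c(Cc3ccccc3)c(=O)oc2c1`, is close: in this assay compound 1 gives 95500 nM, and the step of a 1.8-fold lower number from compound 1 to compound 2 (0.25 log units; within the scatter) stays within the scatter, so the two values cannot be ranked.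

Compound 3 `Cc1ccc2nc(NCC(O)COc3ccc4c(C)c(Cc5ccccc5)c(=O)oc4c3)sc2c1` has not yet been measured. Compared with compound 2, the change is 6-methyl-1,3-benzothiazol-2-yl in place of 3-hydroxypropyl on an amine nitrogen. Going by the values given here, the one measured step, from compound 1 to compound 2, swapped one small chain group for another and moved the number only within the scatter; it does not cover a change in which a hydroxyl-bearing chain gives way to a fused two-ring aromatic group with no hydrogen-bond donor. Among the compounds with values here, no measured pair speaks to this kind of change. Within the data shown here, with only that as a guide, compound 3 is expected to give a lower number in this assay, by an estimated step of a 2.1-fold lower number from compound 2 to compound 3 (0.33 log units; beyond the scatter), though a value within the scatter of compound 2 remains possible. The estimate for compound 3 is 25000 nM, in a range from 8000 nM to 80000 nM.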

Compound 3, half-maximal cytotoxic concentration: > 100000 nM
Compound 3: only a limit was reported; the forecaster's own chance of this, stated with the estimate: 10%; middle value at least 4.0-fold (0.60 log units) from the limit.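

In this assay compound 3 gives only a limit, not a number: the limit of > 100000 nM in this assay, at which 1 of the 3 values shown sits.

Read as floors, the two new comparisons are an at least 1.8-fold higher number from compound 2 to compound 3 (0.27 log units; that floor lies within the scatter) and an at least 1.0-fold higher number from compound 1 to compound 3 (0.01 log units; that floor lies within the scatter), and since both floors lie within the scatter, neither one alone sets compound 3 apart from the compounds it is compared with. What the earlier pair could not show is that the amine nitrogen can carry far more than a small chain without the number dropping: 6-methyl-1,3-benzothiazol-2-yl brings one five-membered and one six-membered aromatic ring and has no hydrogen-bond donor, whereas 3-hydroxypropyl has no ring and has one, yet the cytotoxicity read-out shows no sign of more toxicity.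

The compounds shown cannot say whether this result depends on the whole ring system, on the methyl group, or on the loss of the hydroxyl group. A benzothiazol-2-yl group without the methyl, a single phenyl ring, or a longer chain ending in a carboxylic acid on the same nitrogen would help to separate these possibilities.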